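A few compounds are considered here, and "the series" means these few. Any claim that something is new, unique, unknown or untested is made for them only; others in the source may bear on it.

Measured in a functional assay on A549 cells (Homo sapiens) for antiproliferative activity, read by MTT assay, with a stated time of 72 h; a lower number here means a stronger inhibitor, a higher number a weaker inhibitor:

- compound 1 `C/C=C/C(=O)Nc1cccc(Oc2nc(Nc3cccc(C#N)c3)nc3c2CSCC3)c1` gives 17200 nM
- compound 2 `C/C=C/C(=O)Nc1cccc(Oc2nc(Nc3ccc(OC)cc3)nc3c2CSCC3)c1` gives 22200 nM

Going by the values given here, compound 2 stands level with compound 1, the only other compound measured so far. The step between them, a 1.3-fold higher number from compound 1 to compound 2 (0.11 log units; within the scatter), gives no separation.

The next compound, compound 3 `C/C=C/C(=O)Nc1cccc(Oc2nc(Nc3ccc(OC)nc3)nc3c2CSCC3)c1`, keeps the core of compound 2 and carries 6-methoxypyridin-3-yl in place of 4-methoxyphenyl on a nitrogen on an aromatic ring. Among the compounds with values here, only one measured step bears on this change, as it also replaces the group on that nitrogen. That step, a 1.3-fold higher number from compound 1 to compound 2 (0.11 log units; within the scatter), is small even though it exchanges a 3-cyanophenyl group for a 4-methoxyphenyl group. Within the data shown here, it is thin evidence, however, and no measured compound has a ring with a hetero atom at this place. No shift beyond the scatter is therefore expected in this assay, and the range is kept wide. The expected step is a 1.1-fold lower number from compound 2 to compound 3 (0.05 log units; within the scatter), in no firm direction. For compound 3 the estimated value is 20000 nM, with an expected range from 9000 nM to 45000 nM.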

Compound 3, half-maximal inhibitory concentration: 8040 nM
For compound 3 the middle estimate is 2.5-fold (0.40 log units) above the measured one, outside the stated range (below it).
By their numbers in this assay, from the lowest: compound 3; then compounds 1 and 2 (each within the scatter of the next).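

In this assay, going by these compounds alone, the group on this nitrogen now makes a measurable difference: a 2.8-fold lower number from compound 2 to compound 3 (0.44 log units; beyond the scatter) is the first step at this place to lie beyond the scatter, and it comes as 6-methoxypyridin-3-yl, a six-membered aromatic ring with 1 hetero atom, enters for the carbon-only 4-methoxyphenyl with the number of heavy atoms unchanged. The same group also separates from the 3-cyanophenyl group, with a 2.1-fold lower number from compound 1 to compound 3 (0.33 log units; beyond the scatter) as the second modest step, whereas the two carbon-only rings of compounds 1 and 2 stayed within the scatter of each other, so among these three compounds only the ring with a hetero atom stands apart. Nothing at hand explains why this change lowers the number.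

As far as these compounds go, whether the lower number follows from the ring nitrogen alone or needs the methoxy group with it remains open, and so does the effect of an unsubstituted pyridin-3-yl group or of an ethoxy group or an amine in place of that methoxy group. From the compounds shown here alone, it is also open whether the same exchange would give a step of similar size on another core or in another cell line.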